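The source may hold more compounds than are shown below. What is called first, only, known or untested is meant among the compounds shown, and "the series" means these compounds.

Measured so far:
compound 2 `Cc1cc(OC[C@H](C)COc2ccc(C(=O)CC(C)(C)C)c(O)c2C)ccc1C(=O)O` — 305 nM
compound 1 `Cc1c(OC[C@@H](C)COc2ccc(F)c(C(=O)O)c2)ccc(C(=O)CC(C)(C)C)c1O` — 112 nM

In an assay for positive allosteric modulation of metabotropic glutamate receptor 2 (Rattus norvegicus) (on this read-out higher numbers stand for an effect only at larger amounts of compound and lower numbers for an effect already at smaller amounts), compound 2 gives 305 nM, the highest of the two numbers. Compound 1 gives 112 nM. Among the compounds with values here, the only measured step, a 2.7-fold higher number from compound 1 to compound 2 (0.44 log units; beyond the scatter), exchanges the whole aryl group on the ether oxygen, moving the carboxy group and replacing fluoro with methyl at the same time.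

Compound 3 `Cc1c(OC[C@@H](C)COc2ccc(C(=O)O)c(F)c2)ccc(C(=O)CC(C)(C)C)c1O` is unmeasured. It differs from compound 2 in one place: fluoro in place of methyl on an aromatic carbon. Within the data shown here, no measured step isolates this exchange; the one step in hand bundles it with a shift of the carboxy group, so it only bounds the plausible size of the effect as modest. The expectation for this assay is therefore a step of a 1.3-fold lower number from compound 2 to compound 3 (0.10 log units; within the scatter), with a slightly lower number held more likely than a higher one. Compound 3 is estimated at 240 nM, within a range of 100 nM to 600 nM.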

Compound 3, half-maximal effective concentration: 261 nM
For compound 3 the middle estimate is 1.1-fold (0.04 log units) below the measured one; low and high end bracket the measured number.
By their numbers in this assay, from the lowest: compound 1; then compounds 3 and 2 (each within the scatter of the next).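

In this assay, the exchange of methyl for fluoro ortho to a carboxy group is now seen on its own, and it gives a 1.2-fold lower number from compound 2 to compound 3 (0.07 log units; within the scatter). The other step, a 2.3-fold higher number from compound 1 to compound 3 (0.37 log units; beyond the scatter), has fluoro on both sides and exchanges 3-carboxy-4-fluorophenyl for 4-carboxy-3-fluorophenyl, so the difference between these aryl groups does not depend on methyl being present, and compound 1 keeps the lowest number of the three at 112 nM. No measurement available here bears on the reason for these numbers.

As far as these compounds go, it remains open whether a chloro, methoxy or nitrile group at this position would also stay within the scatter of methyl and fluoro. Also open, from the compounds shown here alone, is how an amide or a tetrazole in place of the carboxy group would read out on either aryl arrangement.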